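The compounds below may be only part of what the source reports. "The series", "measured", "known", "first", "only" and "open" are said of these compounds alone.

Compound 1 (`CN(C)CCCNc1ccc(/N=N/c2ccc([N+](=O)[O-])cc2)cc1`) is one of three compounds examined in an ADME assay on MT4 cells (Homo sapiens) for cytotoxicity, read by MTT assay, with a stated time of 96 h; a higher number here means that more compound is tolerated, a lower number that less compound is tolerated. In this assay compound 1 gives 19000 nM. Compound 2 (`CN(C)CCCN(/N=N/c1cc(F)ccc1F)c1cccc(C(F)(F)F)c1`) gives 16000 nM in this assay, a number that sits within the scatter of the value for compound 1, so the two cannot be told apart. Compound 3 (`Fc1ccc(F)c(/N=N/Nc2cc(F)ccc2F)c1`) reaches only a limit in this assay, >= 100000 nM, and no number is reported for it. This means that (the limit of >= 100000 nM in this assay, at which 1 of the 3 values shown sits).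

Compound 4 (`CN(C)CCCNc1ccc(/N=N/c2ccccc2)cc1`) has not yet been measured in this assay. It differs from compound 1 in one place: hydrogen in place of nitro on an aromatic carbon.

Within the data shown here, no measured pair here shows what such a change does in this assay, and the two available numbers from compound 1 and compound 2 lie within the scatter of each other. The step is therefore expected to be small, a 1.2-fold higher number from compound 1 to compound 4 (0.06 log units; within the scatter), with no direction beyond the scatter. For compound 4 the estimated value in this assay is 22000 nM, within a range from 8000 nM to 60000 nM.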

Compound 4, half-maximal cytotoxic concentration: 17000 nM
Compound 4: the middle estimate sits 1.3-fold (0.11 log units) above what was measured; measured number inside the range.
By their numbers in this assay, from the lowest: compounds 2, 4 and 1 (each within the scatter of the next). At a limit, above all of these: compound 3.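

Among these compounds, the first comparison in this set that differs in only one place shows that, in this assay, hydrogen in place of nitro on an aromatic carbon para to a large group gives a 1.1-fold lower number from compound 1 to compound 4 (0.05 log units; within the scatter) with the rest of the structure unchanged. At this position, the nitro group can therefore be lost with no difference that stands out from the scatter. Nothing among the data shown offers a reason for this outcome.

From the compounds shown here alone, whether an amine, a carboxylic acid or a methoxy group at this same position would also leave the number within the scatter remains open. Also open, going by these compounds, is whether a longer chain in place of the one carried by the shared core would shift the number, and whether the nitro-to-hydrogen step would be as small on another core.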